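Swapping chloro for bromo on the pendant phenyl ring

A few compounds are considered here, and "the series" means these few. Any claim that something is new, unique, unknown or untested is made for them only; others in the source may bear on it.

Of the compounds shown here, two have been measured so far in a functional assay on DLD-1 cells (Homo sapiens) for cytotoxicity, read by MTT assay, with a stated time of 48 h; on this read-out lower numbers stand for stronger inhibition and higher numbers for weaker inhibition. Compound 2 `Cc1ccc2nc(Cl)c(/C=N/n3cc(-c4ccc(Cl)cc4)nc3N)cc2c1` gives 38900 nM, the higher of the two numbers. Compound 1 `Nc1nc(-c2ccc(Br)cc2)cn1/N=C/c1cc2ccccc2nc1Cl`, which carries a 4-bromophenyl group on a different core, gives 23900 nM; the gap between the two numbers lies within the usual scatter, so neither compound can be called the more active one.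

Compound 3 `Cc1ccc2nc(Cl)c(/C=N/n3cc(-c4ccc(Br)cc4)nc3N)cc2c1` has not yet been measured. It differs from compound 2 in a single place: bromo in place of chloro on an aromatic carbon, so that a 4-chlorophenyl group becomes a 4-bromophenyl group. Among the measured compounds shown here, no pair of measured compounds shows this change on its own, so there is no measured step to lean on. Given that compound 1, with the same 4-bromophenyl group, gives 23900 nM, the step from compound 2 to compound 3 is expected to be small, a 1.2-fold lower number from compound 2 to compound 3 (0.07 log units; within the scatter), and not beyond the scatter. Compound 3 is therefore estimated at 33000 nM, within 14000 nM to 80000 nM.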

Compound 3, half-maximal inhibitory concentration: 39300 nM
Estimate against measurement, compound 3: 1.2-fold (0.08 log units) below; the measured number falls inside the stated range.
By their numbers in this assay, from the lowest: compounds 1, 2 and 3 (each within the scatter of the next).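

In this assay, the exchange of the 4-chlorophenyl group for the 4-bromophenyl group gives a 1.0-fold higher number from compound 2 to compound 3 (0.00 log units; within the scatter), so the two halogens cannot be told apart at this position on this read-out. Methyl in place of hydrogen on an aromatic carbon of the core gives a 1.6-fold higher number from compound 1 to compound 3 (0.22 log units; within the scatter), so this second single change cannot be told apart from no change either. No evidence is available on what lies behind these results.

The compounds shown leave open whether a quite different group in place of the halogen, such as an amine, a methoxy group or a carboxylic acid, would shift the number beyond the scatter. On these data alone, whether either halogen counts at all, compared with plain hydrogen at the same place, also remains open.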